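The source may hold more compounds than are shown below. What is called first, only, known or untested is meant among the compounds shown, and "the series" means these compounds.

Measured compounds:
compound 1 `CCCCCOc1nc(N)c2nc(O)n(Cc3ccccc3)c2n1`, 0.01 uM;
compound 2 `Nc1nc(SCc2ccccc2)nc2c1nc(O)n2Cc1ccccc1`, 0.1 uM;
compound 3 `COc1cccc(Cn2c(O)nc3c(N)ncnc32)c1`, 10 uM.

In a functional assay (spleen, spleen) for activation, with Mus musculus as the target (a lower number here means that less compound is needed, a higher number that more compound is needed for the effect), compound 2 gives 0.1 uM, the second highest of the three numbers. Its nearest neighbour is compound 1 with 0.01 uM, and the most distant is compound 3 with 10 uM. Compound 4 `Cc1nc(N)c2nc(O)n(Cc3ccccc3)c2n1` has not yet been measured in this assay. It differs from compound 2 in one place: methyl in place of benzylsulfanyl on an aromatic carbon.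

Within the data shown here, the only measured step that bears on this position is a 10-fold higher number from compound 1 to compound 2 (1.00 log units; beyond the scatter), which shows that exchanging one large group for another at this carbon already moves the number by a sizeable amount. Compound 3, which carries no group at all on that carbon and also differs in its benzyl substituent, stands far higher than compounds 1 and 2. Among the measured compounds shown here, the data give no measured step that tests a small group such as methyl at this place, so the direction of the change rests on the trend from compound 1 through compound 2 to compound 3. On that basis a higher number is expected for compound 4 in this assay than for compound 2, by a 30-fold higher number from compound 2 to compound 4 (1.48 log units; beyond the scatter). Compound 4 is accordingly estimated at 3 uM, with a range from 0.3 uM to 30 uM.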

Compound 4, minimum effective concentration: 1 uM
The estimate for compound 4 lay 3.0-fold (0.48 log units) above the measured number; low and high end bracket the measured number.
By their numbers in this assay, from the lowest: compound 1; then compound 2; then compound 4; then compound 3.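

In this assay, methyl shows how this carbon responds when a substituent of a single heavy atom replaces a larger group, and the number rises (a 10-fold higher number from compound 2 to compound 4 (1.00 log units; beyond the scatter)). The change from pentyloxy to methyl spans more (a 100-fold higher number from compound 1 to compound 4 (2.00 log units; beyond the scatter)), so on this aromatic carbon between two ring nitrogen atoms the three groups rank pentyloxy, then benzylsulfanyl, then methyl, from the lowest number to the highest, with each listed step beyond the scatter. These numbers describe that order but do not explain it, as no supporting evidence bears on the result.

The compounds shown leave open whether the order follows the length of the chain, the atom that joins it to the ring, or the presence of the benzene ring, since pentyloxy, benzylsulfanyl and methyl differ in all three at once. A pentylsulfanyl group, a benzyloxy group or a plain butyl chain on the same carbon would begin to separate these features, and a pentylamino group would test a nitrogen link.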